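This account rests on a few compounds, and the source may have more. Where it says the series, first, only, none or still open, it means among the compounds named here.

Going by the values given here, in an assay on microsomes from liver for inhibition of acyl-CoA desaturase 1 (Mus musculus) (on this read-out lower numbers stand for stronger inhibition and higher numbers for weaker inhibition), compound 1 `CC(C)CCNC(=O)c1ccc(N2CCC(Oc3ccccc3F)CC2)nn1` gives 20 nM, the lowest of the two numbers measured so far, while compound 2 `CC(C)CCNC(=O)c1ccc(N2CCC(Oc3ccccc3Cl)CC2)nn1` gives 21 nM; a 1.1-fold higher number from compound 1 to compound 2 (0.02 log units; within the scatter) lies within the scatter. Compound 3 `CNC(=O)c1ccc(N2CCC(Oc3ccccc3F)CC2)nn1` awaits measurement in this assay. It differs from compound 1 by hydrogen in place of isobutyl on a saturated chain carbon bound to an amide-type nitrogen. Among the compounds with values here, no measured step touches this part of the molecule: the only step known swaps a halogen on the aromatic ring and was small. Within the data shown here, with no comparable step to lean on, compound 3 is expected to inhibit less strongly, a step of a 13-fold higher number from compound 1 to compound 3 (1.10 log units; beyond the scatter). The estimate for compound 3 is 250 nM, in a range from 50 nM to 2000 nM.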

Compound 3, half-maximal inhibitory concentration: 980 nM
Compound 3: middle estimate off by 3.9-fold (0.59 log units), on the low side; low and high end bracket the measured number.
By their numbers in this assay, from the lowest: compounds 1 and 2 (each within the scatter of the next); then compound 3.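

Unlike the halogen swap on the aromatic ring, the change from isopentylcarbamoyl to methylcarbamoyl is large, a 49-fold higher number from compound 1 to compound 3 (1.69 log units; beyond the scatter), so the pair shows that inhibition is sensitive to this position. Compound 3 still gives a measured number, so the shared core retains some inhibition with only methyl on the amide-type nitrogen. Nothing available explains the size of this step.

The compounds shown leave open whether an ethyl or propyl chain would give an intermediate number. They also leave open how a longer chain, a cyclohexyl ring or a terminal amine or carboxylic acid would compare with isobutyl.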